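Cytotoxicity in the hydrazide series: cyano to iodo

The source may report more compounds than this note shows. Statements on the series, on what has been measured and on what is new or still open speak of the compounds shown alone.

Measured compounds and values:
Compound 1, `COC(=O)N[C@H](C(=O)NN(CCC[C@@](O)(Cc1ccccc1)C(=O)N[C@H]1c2ccccc2C[C@H]1O)Cc1ccc(C#N)cc1)C(C)(C)C`: in an ADME assay on MT4 cells (Homo sapiens) for cytotoxicity (a higher number here means that more compound is tolerated, a lower number that less compound is tolerated), compound 1 gives > 10000 nM, which is a limit of the assay and not a number.
Compound 2, `COC(=O)N[C@H](C(=O)NN(CCC[C@@](O)(Cc1ccccc1)C(=O)N[C@H]1c2ccccc2C[C@H]1O)Cc1ccc(-n2ccnc2)cc1)C(C)(C)C`: compound 2 gives > 10000 nM, likewise a limit.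
Compound 3, `COC(=O)N[C@H](C(=O)NN(CCC[C@@](O)(Cc1ccccc1)C(=O)N[C@H]1c2ccccc2C[C@H]1O)Cc1ccc(OCc2cnc(Cl)s2)cc1)C(C)(C)C`: compound 3 gives > 10000 nM, again a limit.

Compound 1 thus stands at the limit of > 10000 nM in this assay, at which 3 of the 3 values shown sit; no finite number is known for it, and the same holds for the two other measured compounds. Within the data shown here, the steps a step that the two limits leave unreadable from compound 1 to compound 2, a step that the two limits leave unreadable from compound 1 to compound 3 and a step that the two limits leave unreadable from compound 2 to compound 3 therefore show only that none of these changes on the benzyl ring brought the value down into the readable region.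

Compound 4, `COC(=O)N[C@H](C(=O)NN(CCC[C@@](O)(Cc1ccccc1)C(=O)N[C@H]1c2ccccc2C[C@H]1O)Cc1ccc(I)cc1)C(C)(C)C`, differs from compound 1 by iodo in place of cyano on an aromatic carbon. No measured step can be read, so the expectation rests on the three limits alone; all three sit at the limit, and the change to iodo is of a kind comparable to the ones already shown. The step that the limit leaves unreadable from compound 1 to compound 4 is expected to be none beyond the scatter, with the value most likely remaining a limit. Compound 4 is therefore expected to give about 12000 nM, with a range from 5000 nM to 30000 nM.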

Compound 4, half-maximal cytotoxic concentration: > 10000 nM
Compound 4 was reported as a limit; the forecaster's own chance of this, stated with the estimate: 75%; the middle value lies beyond the limit too.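

In this assay compound 4 gives > 10000 nM, which is a limit of the assay and not a number. Its steps from compound 1, compound 2 and compound 3 therefore cannot be read. The compounds shown leave open whether any of these four has a finite value in this assay, and how large any difference between them would be.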